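Swapping the benzyl halogens: from compound 3 to compound 4

The source may report more compounds than this note shows. Statements on the series, on what has been measured and on what is new or still open speak of the compounds shown alone.

Compound 1 `O=C(N[C@H]1CCN(Cc2ccc(OC(F)(F)F)cc2)C1)c1ccc(-c2cccs2)cc1`: 78 nM
Compound 2 `O=C(N[C@H]1CCN(Cc2cccc(C(F)(F)F)c2)C1)c1ccc(-c2cccs2)cc1`: 22 nM
Compound 3 `O=C(N[C@H]1CCN(Cc2ccc(Cl)c(Cl)c2)C1)c1ccc(-c2cccs2)cc1`: 15 nM

The three measured compounds share one core and differ only in the aryl group on a saturated chain carbon bound to an amine nitrogen in a ring. In an assay on HEK298 cells for displacement of a labelled ligand from D(4) dopamine receptor (Homo sapiens) (a lower number here means a stronger inhibitor, a higher number a weaker inhibitor), compound 3 gives 15 nM, the lowest number of the three. Going by the values given here, compound 2, at 22 nM, is close to it: the step of a 1.5-fold lower number from compound 2 to compound 3 (0.17 log units; within the scatter) is the only one-place step measured here, and it is small. Compound 1, at 78 nM, lies farther from compound 3, a gap beyond the usual scatter.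

Compound 4 `O=C(N[C@H]1CCN(Cc2ccc(F)cc2)C1)c1ccc(-c2cccs2)cc1` has not yet been measured in this assay. The change from compound 3 is 4-fluorophenyl in place of 3,4-dichlorophenyl on a saturated chain carbon bound to an amine nitrogen in a ring. The step from compound 2 to compound 3 bears on it only loosely, since it kept two substituents on the ring; compound 4 keeps a single fluorine. Compound 1 is the other compound with a single substituent on that ring, and its number is the highest shown, so a move upward is expected, though its size is uncertain. Compound 4 is therefore expected to give 45 nM, with a likely range from 15 nM to 130 nM, an expected step of a 3.0-fold higher number from compound 3 to compound 4 (0.48 log units; beyond the scatter) toward a weaker inhibitor.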

Compound 4, inhibition constant: 5 nM
The estimate for compound 4 lay 9.0-fold (0.95 log units) above the measured number; measured number outside the range, below it.
By their numbers in this assay, from the lowest: compound 4; then compounds 3 and 2 (each within the scatter of the next); then compound 1.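

In this assay, compound 4, with its lone fluoro group, is the strongest inhibitor of the four, as shown by a 3.0-fold lower number from compound 3 to compound 4 (0.48 log units; beyond the scatter) and a 4.4-fold lower number from compound 2 to compound 4 (0.64 log units; beyond the scatter), so this position does not need two substituents or a trifluoromethyl group for a low number. Going by these compounds alone, the largest change, a 16-fold lower number from compound 1 to compound 4 (1.19 log units; beyond the scatter), comes from fluoro in place of trifluoromethoxy on an aromatic carbon, which shows that having only one substituent on the ring does not by itself raise the number: the identity of that substituent matters a great deal here. Nothing available explains why the fluoro compound gives the lowest number.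

The compounds shown leave open how an unsubstituted phenyl group would compare, and so whether the fluoro group lowers the number or the larger groups simply raise it. They also leave open whether 4-chlorophenyl would stay close to 4-fluorophenyl, which would help separate the effect of swapping the halogen from that of removing the second substituent in the step away from 3,4-dichlorophenyl.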